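This account rests on a few compounds, and the source may have more. Where it says the series, first, only, none or still open, it means among the compounds named here.

Of the compounds shown here, three with the same core have been measured in a functional assay on HL-60 cells (Homo sapiens) for antiproliferative activity, with a stated time of 24 h; on this read-out higher numbers stand for weaker inhibition and lower numbers for stronger inhibition. Compound 1 `NC(=O)c1c(NC(=O)c2ccccc2Cl)sc2c1CCNC2`, which carries a hydrogen on the amine nitrogen in its ring, gives 18600 nM. Compound 2 `NC(=O)c1c(NC(=O)c2ccccc2Cl)sc2c1CCN(Cc1ccccc1)C2`, with a benzyl on that nitrogen, gives 12000 nM, and the move a 1.6-fold lower number from compound 1 to compound 2 (0.19 log units; within the scatter) stays within the scatter. Compound 3 `NC(=O)c1c(NC(=O)c2ccccc2Cl)sc2c1CCN(C(=S)Nc1ccccc1F)C2`, with a (2-fluorophenyl)amino thiocarbonyl group on that nitrogen, gives 4970 nM; the moves a 3.7-fold lower number from compound 1 to compound 3 (0.57 log units; beyond the scatter) and a 2.4-fold lower number from compound 2 to compound 3 (0.38 log units; beyond the scatter) are both modest but beyond the scatter, so compound 3 stands lowest of the three numbers.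

Compound 4 `NC(=O)c1c(NC(=O)c2ccccc2Cl)sc2c1CCN(C(=S)Nc1ccccc1C(F)(F)F)C2` differs from compound 3 by trifluoromethyl in place of fluoro on an aromatic carbon, that is, 2-fluorophenyl becomes 2-(trifluoromethyl)phenyl, with the new group sitting ortho to a large group. Within the data shown here, none of the measured steps touches this outer ring: all three steps change what hangs on the amine nitrogen in the ring, not the aryl attached to the thiocarbonyl. Among the measured compounds shown here, there is therefore no measured step that tells how large this change might be, and the expected step of a 1.1-fold lower number from compound 3 to compound 4 (0.04 log units; within the scatter) is estimated to stay within the scatter. Compound 4 is expected to give about 4500 nM in this assay, with a range from 1500 nM to 13000 nM.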

Compound 4, half-maximal inhibitory concentration: 10600 nM
For compound 4 the middle estimate is 2.4-fold (0.37 log units) below the measured one; the range from low to high includes it.
By their numbers in this assay, from the lowest: compound 3; then compounds 4, 2 and 1 (each within the scatter of the next).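

The outer aromatic ring is not a neutral part of the molecule in this assay: changing only the group on its aromatic carbon, with trifluoromethyl in place of fluoro, gives a 2.1-fold higher number from compound 3 to compound 4 (0.33 log units; beyond the scatter). This step is modest but beyond the scatter. Higher numbers stand for weaker inhibition, so the larger fluorinated group goes with weaker inhibition in this one pair. The earlier steps all changed what hangs on the amine nitrogen in the ring, whereas this one keeps the thiocarbonyl link in place and shows that the read-out also responds to a change further out, though nothing measured here accounts for the shift.

From the compounds shown here alone, with only fluoro and trifluoromethyl to compare, one pair cannot show a trend at this position, so it remains open how a chlorine, a methyl, a methoxy or a plain hydrogen on the same aromatic carbon would read. Going by these compounds, it also remains open whether the same change would have a similar effect if a carbonyl took the place of the thiocarbonyl.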